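Ether Linker Swap on an Inactive Antiproliferative Scaffold

The compounds below may be only part of what the source reports. "The series", "measured", "known", "first", "only" and "open" are said of these compounds alone.

The shared core carries a trifluoromethyl benzamide and appears in compound 1 `Cc1ccc(NC(=O)c2cccc(C(F)(F)F)c2)cc1N1Cc2cnc(OC3CCN(C(=O)OC(C)(C)C)CC3)nc2N(C)C1=O` and compound 2 `CNc1cc(Nc2ncc3c(n2)N(C)C(=O)N(c2cc(NC(=O)c4cccc(C(F)(F)F)c4)ccc2C)C3)ccc1C`. In an ADME assay on BaF3 cells (Mus musculus) for antiproliferative activity, read by CellTiter-Glo and CCK-8 assay, with a stated time of 72 h (on this read-out higher numbers stand for weaker inhibition of growth and lower numbers for stronger inhibition of growth), compound 1 gives only a limit of the assay, > 10000 nM, and no number. In this assay compound 2 likewise gives only a limit, > 10000 nM, so its standing on the numbers shown is simply that of a compound without measurable growth inhibition. Both results sit at the limit of > 10000 nM in this assay, at which 2 of the 2 values shown sit.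

Compound 3 `Cc1ccc(Oc2ncc3c(n2)N(C)C(=O)N(c2cc(NC(=O)c4cccc(C(F)(F)F)c4)ccc2C)C3)cc1N` is not yet measured. It differs from compound 2 by 3-amino-4-methylphenoxy in place of (4-methyl-3-(methylamino)phenyl)amino on an aromatic carbon. Among the compounds with values here, with both measured compounds at the limit, no step is known; the change is expected to leave activity at or near that limit, with no movement beyond the scatter, and a number no higher from compound 2 to compound 3 (the limit leaves the size open) is the expected step. For compound 3 the estimate in this assay is 10000 nM, within 3000 nM to 30000 nM.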

Compound 3, concentration for 50% growth inhibition: > 10000 nM
Compound 3: no number, only a limit; the forecaster's own chance of this, stated with the estimate: 75%; the middle value sits exactly at the limit.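

In this assay, within the data shown here, compound 3 gives only a limit, as compound 2 does, so no step between compound 2 and compound 3 can be read: the limit of > 10000 nM in this assay, at which 3 of the 3 values shown sit. The compounds shown leave open which change on the shared core, if any, would bring growth inhibition into a measurable range.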